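Methoxy in place of hydrogen, repeated in a second core

The compounds below may be only part of what the source reports. "The series", "measured", "known", "first", "only" and "open" are said of these compounds alone.

Compound 1 `COC1Cc2cc(-c3ccccc3)sc2C2(CCN(Cc3ccccc3)CC2)O1` and compound 3 `COC1Cc2c(-c3ccccc3)csc2C2(CCN(Cc3ccccc3)CC2)O1` are built from the same atoms joined differently; the difference between the two cores is not broken down here. Going by the values given here, in an assay on membranes from brain for displacement of a labelled ligand from Sigma non-opioid intracellular receptor 1 (Cavia porcellus), read by scintillation counting, with a stated time of 120 min (a lower number here means a stronger inhibitor, a higher number a weaker inhibitor), compound 1 gives 16 nM, while compound 3 gives 5.4 nM, the lowest of the three numbers measured so far. Compound 2 `COc1ccc(-c2cc3c(s2)C2(CCN(Cc4ccccc4)CC2)OC(OC)C3)cc1` differs from compound 1 by methoxy in place of hydrogen on an aromatic carbon, which cut one bond further out reads phenyl to 4-methoxyphenyl. In this assay compound 2 gives 56 nM, so that a 3.5-fold higher number from compound 1 to compound 2 (0.54 log units; beyond the scatter) is a modest weakening that still lies beyond the scatter.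

Compound 4 `COc1ccc(-c2csc3c2CC(OC)OC32CCN(Cc3ccccc3)CC2)cc1` stands to compound 3 as compound 2 stands to compound 1, the difference being (methoxy in place of hydrogen on an aromatic carbon). The place is described in the same words for both pairs, so this is the same change, carried into the core of compound 3 rather than the core of compound 1. Among the compounds with values here, the step of a 3.5-fold higher number from compound 3 to compound 4 (0.55 log units; beyond the scatter) is expected to sit beside a 3.5-fold higher number from compound 1 to compound 2 (0.54 log units; beyond the scatter), because the only measured instance of this change is a 3.5-fold higher number from compound 1 to compound 2 (0.54 log units; beyond the scatter) and nothing among the three measured compounds argues that the second core should answer differently. Within the data shown here, the value for compound 4 in this assay is accordingly estimated at 19 nM, with the expected range running from 8 nM to 45 nM to allow for the change having been measured in only one core.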

Compound 4, inhibition constant: 7.1 nM
Estimate against measurement, compound 4: 2.7-fold (0.43 log units) above; the measured number lies below the stated range.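

In this assay, methoxy in place of hydrogen on an aromatic carbon does not give the same step in the two cores, so a step read in the core of compound 1 cannot simply be transferred to the core of compound 3: the same change on two cores in this assay, a 3.5-fold higher number (0.54 log units; beyond the scatter) from compound 1 to compound 2 and a 1.3-fold higher number (0.12 log units; within the scatter) from compound 3 to compound 4, 2.7-fold (0.43 log units) apart, beyond the scatter of two such steps. In the core of compound 3 the step is a 1.3-fold higher number from compound 3 to compound 4 (0.12 log units; within the scatter), which means that phenyl and 4-methoxyphenyl cannot be told apart there in this read-out, whereas the same change in the core of compound 1 gives a modest weakening that lies beyond the scatter. This rests on a single pair in each core and a single substituent, so it shows that the core can matter for this change, but it gives no general rule for the series and no reason why the two cores part.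

Going by these compounds, whether the two cores also diverge for other groups at the same place on the phenyl ring, such as an amine, a carboxylic acid or a longer chain like butoxy, remains open. Also open, on these data alone, is whether the same divergence would appear in a read-out at any other receptor.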